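The source may hold more compounds than are shown below. What is called first, only, known or untested is meant among the compounds shown, and "the series" means these compounds.

In a functional assay on HCT-116 cells (Homo sapiens) for cytotoxicity, read by MTT assay, with a stated time of 72 h (on this read-out higher numbers stand for lower toxicity in this test and lower numbers for higher toxicity in this test), compound 3 (`CCOC(=O)c1c(O)c2cc(Cc3ccccc3)ccc2n(C)c1=O`) gives > 10000 nM, which is a limit of the assay and not a number. Compound 2 (`CCOC(=O)c1c(O)c2cc(OC)ccc2n(C)c1=O`) gives > 10000 nM, which is also a limit. Compound 1 (`Cn1c(=O)c(C(=O)O)c(O)c2cc(Cc3ccc(F)cc3)ccc21`), which bears a 4-fluorobenzyl group, gives > 10000 nM, again a limit. The whole picture so far is the limit of > 10000 nM in this assay, at which 3 of the 3 values shown sit.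

Compound 4 (`CCOC(=O)c1c(O)c2cc(Cc3ccc(F)cc3)ccc2n(C)c1=O`) differs from compound 3 in one place, where benzyl becomes 4-fluorobenzyl: fluoro in place of hydrogen on an aromatic carbon. Among the compounds with values here, the only measured step between two compounds that differ in one place is a step that the two limits leave unreadable from compound 2 to compound 3, and it offers no size to carry over. With so little to go on, the safest expectation is no change beyond the usual scatter, and a result reported only as a limit is the most likely outcome. The expected change is a step that the limit leaves unreadable from compound 3 to compound 4, an estimate that points in neither direction. For compound 4 the estimated half-maximal cytotoxic concentration is 12000 nM, with an expected range from 5000 nM to 30000 nM.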

Compound 4, half-maximal cytotoxic concentration: > 10000 nM
Compound 4 gave a limit, no number; the forecaster's own chance of this, stated with the estimate: 85%; the middle value lies beyond the limit too.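

Compound 4 sits at the same kind of limit as compounds 1, 2 and 3, so no step from any of them to compound 4 can be read: the limit of > 10000 nM in this assay, at which 4 of the 4 values shown sit.

The compounds shown leave open whether any of these changes, fluoro included, alters the result in this assay.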